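This account rests on a few compounds, and the source may have more. Where it says the series, first, only, none or still open, it means among the compounds named here.

Compound 1 `COc1ccc(-c2cc(-c3ccc(NS(C)(=O)=O)cc3)cnc2N)cn1` was examined in an in vitro ADME assay on microsomes from liver (Homo sapiens) for metabolic stability; a higher number here means that the compound lasts longer, a lower number that the compound disappears faster. In this assay compound 1 gives > 4.16 h, which is a limit rather than a number. Compound 2 `COc1ccc(-c2cc(-c3ccc(S(C)(=O)=O)cc3C(F)(F)F)cnc2N)cn1` gives > 4.16 h in this assay, likewise a limit. Compound 3 `COc1ccc(-c2cnc(N)c(-c3ccc(OC)nc3)c2)cn1` gives 1.45 h in this assay. Compound 1 therefore sits at the limit of > 4.16 h in this assay, at which 2 of the 3 values shown sit, with no number of its own. Compound 4 `COc1ccc(-c2cc(-c3ccc(C(=O)N(C)C)cc3)cnc2N)cn1` differs from compound 1 by dimethylcarbamoyl in place of methanesulfonamido on an aromatic carbon. Among the compounds with values here, no measured pair shows this change, so its effect is unknown. The step of an at least 1.1-fold lower number from compound 1 to compound 4 (0.07 log units; that floor lies within the scatter) is expected to be small, either toward a shorter half-life or none beyond the scatter. Compound 4 is expected to give 3.5 h in this assay, with a range from 1.5 h to 6 h.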

Compound 4, half-life: 2.6 h
Compound 4: the middle estimate sits 1.3-fold (0.13 log units) above what was measured; the range from low to high includes it.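

The earlier compounds shown here held no pair for this change; now dimethylcarbamoyl in place of methanesulfonamido, on an aromatic carbon para to a large group, gives an at least 1.6-fold lower number from compound 1 to compound 4 (0.20 log units; that floor lies within the scatter) in this assay. Compound 4, at 2.6 h, gives this position a number rather than a limit. The step is only a floor, since compound 1 has a limit and no number of its own: the limit of > 4.16 h in this assay, at which 2 of the 4 values shown sit.

On these data alone, how far compound 1 lies past its limit remains open, and so does whether the true step exceeds the scatter. Also open, as far as these compounds go, is how a carboxylic acid or an amine at this position would fare in this assay.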